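Swapping formyl for 2-benzoylethenyl in a cytotoxicity test

The compounds below may be only part of what the source reports. "The series", "measured", "known", "first", "only" and "open" are said of these compounds alone.

In a functional assay on Raji cells (Homo sapiens) for cytotoxicity, with a stated time of 72 h (a higher number here means that more compound is needed for the effect, a lower number that less compound is needed), compound 1 (`C=C[C@@](C)(/C=C/c1ccc(O)cc1)CCC=O`) gives > 26000 nM as its reading, which is a limit and not a number. Going by the values given here, compound 2 (`COc1ccc(/C=C/[C@@](C)(/C=C/c2ccc(O)c(C=O)c2)CCC=C(C)C)cc1`) gives 13000 nM as the only actual number so far. Compound 3 (`COc1ccc(/C=C/[C@@](C)(/C=C/c2ccc(O)c(/C=C/C(=O)c3ccccc3)c2)CCC=C(C)C)cc1`) carries 2-benzoylethenyl in place of the formyl of compound 2 on an aromatic carbon, ortho to a hydroxy group (2-benzoylethenyl in place of formyl on an aromatic carbon). Among the compounds with values here, no measured pair shows this kind of change, so any forecast is uncertain. The expected step (a 2.2-fold lower number from compound 2 to compound 3 (0.34 log units; beyond the scatter)) is modest, towards less compound needed. Compound 3 is estimated at 6000 nM in this assay, with 1500 nM to 20000 nM as the expected range.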

Compound 3, half-maximal effective concentration: > 26000 nM
Compound 3: only a limit was reported; the forecaster's own chance of this, stated with the estimate: 10%; middle value at least 4.3-fold (0.63 log units) away from the limit.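

Going by these compounds alone, on this aromatic carbon, ortho to a hydroxy group, the swap gives the first measured step in this assay: an at least 2.0-fold higher number from compound 2 to compound 3 (0.30 log units; that floor lies within the scatter). Putting 2-benzoylethenyl in place of formyl brought no lower number, and compound 3 gives only a limit, not a number. The size of the step cannot be read any further, because the reading ends at a limit: the limit of > 26000 nM in this assay, at which 2 of the 3 values shown sit.

The compounds shown leave open how an amine or a carboxylic acid in place of formyl would read at this position. They also cannot separate the part played by the aromatic ring of 2-benzoylethenyl from that of its double bond.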